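A few compounds are considered here, and "the series" means these few. Any claim that something is new, unique, unknown or untested is made for them only; others in the source may bear on it.

Series notes, whole-organism read-out. In a functional assay on the whole organism (strain Wistar) for inhibition, with Rattus norvegicus as the target, read by paw edema, with stated times of 1 h and 3 h, at a dose of 200 mg/kg by the oral route (on this read-out higher numbers stand for more inhibition at the one dose given (going by the name of the read-out) and lower numbers for less inhibition), compound 1 `Cc1cccc(N(C)CC2CCC/C(=C\c3ccc(S(C)(=O)=O)cc3)C2=O)c1` gives 36.2%. Compound 2 `Cc1ccc(N(C)CC2CCC/C(=C\c3ccccc3)C2(O)c2ccccc2)cc1` gives 59.6% in this assay, the highest of the three numbers. Compound 3 `COc1ccc(C2(O)/C(=C/c3ccccc3)CCCC2CN(C)c2ccc(C)cc2)cc1` gives 21.3% in this assay and so stands lowest of the three, beyond the scatter below compound 1 and beyond the scatter below compound 2. Among the compounds with values here, the only single-point step among the measured compounds is a number 38.3 percentage points lower from compound 2 to compound 3 (beyond the scatter), a large drop.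

Compound 4 `COc1ccc(C2(O)/C(=C/c3ccc(C)cc3)CCCC2CN(C)c2ccc(C)cc2)cc1` is not yet measured. It differs from compound 3 by methyl in place of hydrogen on an aromatic carbon. Within the data shown here, no measured pair differs only in a methyl against a hydrogen on an aromatic carbon, so nothing bears directly on this step; the one step recorded concerns methoxy in place of hydrogen and cannot be carried over. Compound 1 and compound 2 both carry a methyl on an aromatic ring but differ from each other in more than one place, so their two values give no clean reading either. In the absence of a bearing step, the expected change from compound 3 to compound 4 is a number 1.7 percentage points higher from compound 3 to compound 4 (within the scatter), not beyond the scatter. For compound 4 the estimated value in this assay is 23%, with a range from 8% to 40%.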

Compound 4, a percentage reported as inhibition, in the whole organism at one dose (the size of the read-out at that dose, not a potency): 29.8%
Compound 4: the middle estimate sits 6.8 percentage points below what was measured; the measured number falls inside the stated range.
By their numbers in this assay, from the lowest: compounds 3, 4 and 1 (each within the scatter of the next, the first and the last beyond it); then compound 2.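

Working notes on the methyl step. In this assay, within the data shown here, methyl in place of hydrogen on an aromatic carbon of a six-membered aromatic ring of carbon only, para to a large group (phenyl to 4-methylphenyl), gives a number 8.5 percentage points higher from compound 3 to compound 4 (within the scatter) and is the first reading of this change, with the two compounds not separated on this read-out. The methoxy step, a number 38.3 percentage points lower from compound 2 to compound 3 (beyond the scatter), lies beyond the scatter, whereas this methyl step does not, but the two steps differ in both the group and the ring carrying it, so neither can stand in for the other. No measurement here offers an explanation for the size of the methyl step.

Going by these compounds, whether the same methyl would read the same way on the core of compound 2, which carries no methoxy, remains open, and a single step from a parent with a low number says little about the position in general. Also open, on these data alone, is what an ethyl group, a chlorine atom or a carboxylic acid in place of this methyl would give in this assay at the same place on the ring.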